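One Aryl Swap Carried Across Two Cores

The compounds below may be only part of what the source reports. "The series", "measured", "known", "first", "only" and "open" are said of these compounds alone.

Compound 1 `NC(=O)[C@@H]1CCCN1C(=O)CCCCCN1CCN(c2cccc(Cl)c2Cl)CC1` and compound 3 `NC(=O)[C@@H]1Cc2ccccc2CN1C(=O)CCCCCN1CCN(c2cccc(Cl)c2Cl)CC1` share the 2,3-dichlorophenyl group on an amine nitrogen in a ring but rest on different cores; the difference between the two cores is not broken down here. In an assay on HEK293 cells for displacement of a labelled ligand from 5-hydroxytryptamine receptor 7 (Homo sapiens), with a stated time of 1 h (on this read-out lower numbers stand for stronger inhibition and higher numbers for weaker inhibition), compound 1 gives 179 nM, and compound 3 gives 95 nM; these two values lie within the scatter of each other, so no order between them is claimed. Compound 2 `NC(=O)[C@@H]1CCCN1C(=O)CCCCCN1CCN(c2noc3ccccc23)CC1` carries the change a group of 9 heavy atoms (7 carbon, 1 nitrogen, 1 oxygen; one five-membered aromatic ring with 2 hetero atoms, one six-membered aromatic ring of carbon only) in place of a group of 8 heavy atoms (6 carbon, 2 chlorine; one six-membered aromatic ring of carbon only), on an amine nitrogen in a ring on the core of compound 1; in this assay compound 2 gives 50 nM, which amounts to a 3.6-fold lower number from compound 1 to compound 2 (0.55 log units; beyond the scatter). Compound 4 `NC(=O)[C@@H]1Cc2ccccc2CN1C(=O)CCCCCN1CCN(c2noc3ccccc23)CC1` carries the same change on the core of compound 3, namely (a group of 9 heavy atoms (7 carbon, 1 nitrogen, 1 oxygen; one five-membered aromatic ring with 2 hetero atoms, one six-membered aromatic ring of carbon only) in place of a group of 8 heavy atoms (6 carbon, 2 chlorine; one six-membered aromatic ring of carbon only), on an amine nitrogen in a ring), at a place described in the same words. Among the four compounds this change occurs twice, once measured. The step to compound 4 in this assay is expected to be a 3.5-fold lower number from compound 3 to compound 4 (0.55 log units; beyond the scatter), because the same change already produced a 3.6-fold lower number from compound 1 to compound 2 (0.55 log units; beyond the scatter); this rests on a single pair, so it is held loosely. Compound 4 is therefore estimated at 27 nM in this assay, with a likely range from 10 nM to 75 nM.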

Compound 4, inhibition constant: 22 nM
For compound 4 the middle estimate is 1.2-fold (0.09 log units) above the measured one; the measured number falls inside the stated range.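

In this assay, replacing the 2,3-dichlorophenyl group with the group that brings the five-membered aromatic ring gives a 4.3-fold lower number from compound 3 to compound 4 (0.64 log units; beyond the scatter), and the step keeps its size when it is carried from one core to the other: the same change on two cores in this assay, a 3.6-fold lower number (0.55 log units; beyond the scatter) from compound 1 to compound 2 and a 4.3-fold lower number (0.64 log units; beyond the scatter) from compound 3 to compound 4, 1.2-fold (0.08 log units) apart, within the scatter of two such steps. Across these four compounds, then, the change behaves as additive with the difference between the two cores, and neither pair goes against this. Among the compounds shown here, the agreement rests on only two pairs, however, so it does not show that the step would hold on any further core or for any other group leaving the amine nitrogen, and it gives no reason why the two steps agree.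

The compounds shown leave open whether a plain phenyl group or a pyridine ring on that same amine nitrogen would follow the same course on both cores. Also open, going by these compounds, is whether the step would survive a shorter or longer chain, or a carboxylic acid or nitrile in place of the amide on the core.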